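The source may report more compounds than this note shows. Statements on the series, on what has been measured and on what is new or still open speak of the compounds shown alone.

Of the compounds shown here, three of a shared core have been measured in an assay on membranes from brain for displacement of a labelled ligand from Sigma non-opioid intracellular receptor 1 (Cavia porcellus), read by scintillation counting, with a stated time of 120 min, in the presence of a further agent that is not named here; a higher number here means a weaker inhibitor, a lower number a stronger inhibitor. Compound 1 `c1ccc(CNC[C@@H]2COC[C@H](c3ccccc3)O2)cc1` gives 155 nM. Compound 2 `c1ccc(CNCCC2COCC(c3ccccc3)(c3ccccc3)O2)cc1` gives 502 nM, the highest of the three numbers; its nearest neighbour is compound 1, and the gap between them lies beyond the usual scatter. Compound 3 `c1ccc(CNCC2COC(c3ccccc3)(c3ccccc3)CO2)cc1` gives 7.37 nM, the lowest of the three, far from compound 2 and also beyond the scatter. No pair among these compounds differs in only one place, so no single step can be read from them directly.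

Compound 4 `NCC1COCC(c2ccccc2)(c2ccccc2)O1` has not yet been measured. It differs from compound 2 as follows: amino in place of (benzylamino)methyl on a saturated chain carbon bound to a saturated ring carbon. The group that leaves carries one six-membered aromatic ring of carbon only and eight carbon atoms; the group that enters is a single nitrogen atom, the amino group.

Because compound 2 already gives 502 nM with the (benzylamino)methyl group in place, and the change to compound 4 removes that whole group, the author expects the number to rise, with a step of a 12-fold higher number from compound 2 to compound 4 (1.08 log units; beyond the scatter) well beyond the scatter. Compound 4 is therefore estimated at 6000 nM, within a range from 1200 nM to 30000 nM.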

Compound 4, inhibition constant: > 10000 nM
Compound 4: only a limit was reported (the forecaster's own chance of this, stated with the estimate: 20%); middle value at least 1.6-fold (0.22 log units) from the limit.
By their numbers in this assay, from the lowest: compound 3; then compound 1; then compound 2. At a limit, above all of these: compound 4.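

In this assay compound 4 gives > 10000 nM, and this value is a limit of the assay, not a number. Amino in place of (benzylamino)methyl on a saturated chain carbon bound to a saturated ring carbon gives an at least 19-fold higher number from compound 2 to compound 4 (1.29 log units; beyond the scatter), the first single change that can be read in this set, and it shows that losing the whole group at this place costs a large step even from the highest of the earlier numbers. Going by these compounds, the true size of that step stays unknown, as it is bounded on one side only: the limit of > 10000 nM in this assay, at which 1 of the 4 values shown sits.

The compounds shown leave open which part of the departing group accounts for the step, a question that a simple methylamino group, a dimethylamino group or a phenethylamino group at the same place could help to answer. They also leave open whether amino in place of the corresponding group on the core of compound 3, which gives 7.37 nM, would bring a step of similar size.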